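The source may report more compounds than this note shows. Statements on the series, on what has been measured and on what is new or still open speak of the compounds shown alone.

In a functional assay on HGC-27 cells (Homo sapiens) for inhibition, read by MTT assay, with a stated time of 72 h (a lower number here means a stronger inhibitor, a higher number a weaker inhibitor), compounds that share one core and differ only in the group on sulfur give a first picture. Compound 1 `Cc1cc(N2CC[C@@H](C)[C@@H](N(C)c3ncnc4[nH]ccc34)C2)n2nc(SCc3ccccc3)nc2n1`, with a plain phenyl, gives 13900 nM. Compound 3 `Cc1cc(N2CC[C@@H](C)[C@@H](N(C)c3ncnc4[nH]ccc34)C2)n2nc(SCc3ccc(Br)cc3)nc2n1`, the 4-bromobenzyl member, gives 19500 nM, and it stands level with compound 1, since a 1.4-fold higher number from compound 1 to compound 3 (0.15 log units; within the scatter) lies within the scatter. For compound 2 `Cc1cc(N2CC[C@@H](C)[C@@H](N(C)c3ncnc4[nH]ccc34)C2)n2nc(SCc3ccc(F)c(Cl)c3)nc2n1`, this assay reports only a limit, > 100000 nM. Compound 4 `Cc1cc(N2CC[C@@H](C)[C@@H](N(C)c3ncnc4[nH]ccc34)C2)n2nc(SCc3ccc([N+](=O)[O-])cc3)nc2n1` carries nitro in place of bromo on an aromatic carbon, para to a large group (nitro in place of bromo on an aromatic carbon). The closest guide is compound 3 itself, where adding bromo gave a 1.4-fold higher number from compound 1 to compound 3 (0.15 log units; within the scatter). The other measured steps, an at least 7.1-fold higher number from compound 1 to compound 2 (0.85 log units; beyond the scatter) and an at least 5.1-fold lower number from compound 2 to compound 3 (0.70 log units; beyond the scatter), show that changes on this phenyl can matter, but both rest on a limit and neither involves nitro. No clear direction follows, so a step beyond the scatter is not expected, though a weaker result remains possible. The expected change is a 1.1-fold higher number from compound 3 to compound 4 (0.05 log units; within the scatter). Compound 4 is estimated at about 22000 nM, with an expected range of 8000 nM to 70000 nM.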

Compound 4, half-maximal inhibitory concentration: 29400 nM
For compound 4 the middle estimate is 1.3-fold (0.13 log units) below the measured one, within the range that was stated.
By their numbers in this assay, from the lowest: compounds 1, 3 and 4 (each within the scatter of the next, the first and the last beyond it). At a limit, above all of these: compound 2.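

Swapping bromo for nitro on this ring carbon, with a 1.5-fold higher number from compound 3 to compound 4 (0.18 log units; within the scatter), leaves the two groups indistinguishable in this assay, even though nitro brings more heavy atoms and two hydrogen-bond acceptors. Set against the plain phenyl of compound 1, however, nitro gives a small but real loss, with a 2.1-fold higher number from compound 1 to compound 4 (0.33 log units; beyond the scatter), whereas the bromo step from that same compound stayed within the scatter. Compound 4 also sits clearly apart from compound 2, with an at least 3.4-fold lower number from compound 2 to compound 4 (0.53 log units; beyond the scatter), but that step has no fixed size, as it rests on a limit: the limit of > 100000 nM in this assay, at which 1 of the 4 values shown sits.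

The compounds shown leave open whether the 3-chloro or the 4-fluoro part of compound 2 matters more, since the two appear only together. Going by these compounds, how an amine or a carboxylic acid on this same ring carbon would read also remains unknown.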